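Swapping a Polar Side Chain for a Single Fluorine

The source may report more compounds than this note shows. Statements on the series, on what has been measured and on what is new or still open speak of the compounds shown alone.

Measured so far, in an assay on isolated protein for inhibition of ubiquitin carboxyl-terminal hydrolase 7 (Homo sapiens), with stated times of 30 min and 2 h; on this read-out lower numbers stand for stronger inhibition and higher numbers for weaker inhibition:
compound 1, `Cn1nc2c(=O)n(CC3(O)CCN(Cc4ccc(-c5ccco5)cc4Cl)CC3)cnc2c1-c1ccc(C(F)(F)F)cc1`, 530 nM
compound 2, `Cn1nc2c(=O)n(CC3(O)CCN(Cc4ccc(-c5ccco5)cc4Cl)CC3)cnc2c1-c1ccc(CNS(C)(=O)=O)cc1`, 65.3 nM
compound 3, `Cn1nc2c(=O)n(CC3(O)CCN(Cc4ccc(-c5ccco5)cc4Cl)CC3)cnc2c1-c1ccc(CNCCO)cc1`, 8.2 nM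

Compound 3 sits at the lowest number of the three, and both of its neighbours lie beyond the usual scatter: compound 2 is an 8.0-fold lower number from compound 2 to compound 3 (0.90 log units; beyond the scatter), and compound 1 is a 65-fold lower number from compound 1 to compound 3 (1.81 log units; beyond the scatter). Within this small set, compound 3 is therefore the strongest inhibitor.

Compound 4, `Cn1nc2c(=O)n(CC3(O)CCN(Cc4ccc(-c5ccco5)cc4Cl)CC3)cnc2c1-c1ccc(F)cc1`, differs from compound 3 at one point on the shared core: fluoro in place of ((2-hydroxyethyl)amino)methyl on an aromatic carbon. The group that leaves carries two hydrogen-bond donors and two acceptors; the fluoro that enters carries none.

Two measured steps speak to this. Going from compound 1, which bears a trifluoromethyl at the same position, to compound 3 gave a 65-fold lower number from compound 1 to compound 3 (1.81 log units; beyond the scatter), and the intermediate route through compound 2 gave an 8.1-fold lower number from compound 1 to compound 2 (0.91 log units; beyond the scatter) followed by an 8.0-fold lower number from compound 2 to compound 3 (0.90 log units; beyond the scatter). Both routes say that a substituent with hydrogen-bond donors and acceptors at this carbon brings a much lower number than a plain halogenated group. Among the measured compounds shown here, no measured compound carries fluoro here, so the size of the step is uncertain, but a return toward the level of compound 1 is the natural expectation.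

For compound 4 the expected value in this assay is 600 nM, within 150 nM to 2500 nM, which would amount to a 73-fold higher number from compound 3 to compound 4 (1.86 log units; beyond the scatter).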

Compound 4, half-maximal inhibitory concentration: 64.5 nM
For compound 4 the middle estimate is 9.3-fold (0.97 log units) above the measured one; measured number below the stated range.
By their numbers in this assay, from the lowest: compound 3; then compounds 4 and 2 (each within the scatter of the next); then compound 1.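

A single fluoro at this aromatic carbon already gives a much lower number than trifluoromethyl in this assay (an 8.2-fold lower number from compound 1 to compound 4 (0.91 log units; beyond the scatter)), so a group need not carry hydrogen-bond donors or acceptors to improve on compound 1. The new result also shows that the substituents with a chain at this position do not all outperform the small atom: compound 4 cannot be told apart from the compound with the (methanesulfonamido)methyl group (a 1.0-fold lower number from compound 2 to compound 4 (0.01 log units; within the scatter)). Only ((2-hydroxyethyl)amino)methyl keeps a clear edge over fluoro (a 7.9-fold higher number from compound 3 to compound 4 (0.90 log units; beyond the scatter)), which makes that edge a feature of this particular group, not of size or of added chain length across the set.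

The compounds shown leave open which part of that group carries the edge, the amine nitrogen or the terminal hydroxyl, and a plain aminomethyl group or a longer chain ending in a hydroxyl, such as 3-hydroxypropylamino on the same methyl, would help separate the two. Nothing available here explains why fluoro sits so far below trifluoromethyl or why the amine side chain stays ahead of it.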